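Swapping Fluoro for Tert-Butyl on the Carbonyl Compound

The source may hold more compounds than are shown below. What is called first, only, known or untested is meant among the compounds shown, and "the series" means these compounds.

Measured compounds and their values in a functional assay on MCF7 cells (Homo sapiens) for inhibition, read by MTT assay, with a stated time of 48 h; a lower number here means a stronger inhibitor, a higher number a weaker inhibitor:
compound 1 `COc1cc(N(Cc2nc3ccccc3[nH]2)S(=O)(=O)c2ccc(C)cc2)cc(OC)c1OC` gives 5400 nM
compound 2 `COc1cc(N(Cc2nc3ccccc3[nH]2)S(=O)(=O)c2ccccc2)cc(OC)c1OC` gives 27300 nM
compound 3 `COc1cc(N(Cc2nc3ccccc3[nH]2)C(=O)c2ccc(F)cc2)cc(OC)c1OC` gives 45200 nM

Compound 3 stands highest of the three in this assay: a 1.7-fold higher number from compound 2 to compound 3 (0.22 log units; within the scatter), and an 8.4-fold higher number from compound 1 to compound 3 (0.92 log units; beyond the scatter). Compound 4 `COc1cc(N(Cc2nc3ccccc3[nH]2)C(=O)c2ccc(C(C)(C)C)cc2)cc(OC)c1OC` differs from compound 3 in one place: tert-butyl in place of fluoro on an aromatic carbon. Going by the values given here, no measured step changes this position on a carbonyl compound. The nearest guide is a 5.1-fold higher number from compound 1 to compound 2 (0.70 log units; beyond the scatter), where a methyl on an aromatic carbon was replaced by hydrogen and the number rose. Putting a tert-butyl where compound 3 has fluoro may therefore move the number down, but that guide comes from sulfonyl compounds, so the expectation is loose. Compound 4 is estimated at 20000 nM, between 6000 nM and 60000 nM, an expected 2.3-fold lower number from compound 3 to compound 4 (0.35 log units; beyond the scatter).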

Compound 4, half-maximal inhibitory concentration: 48800 nM
The estimate for compound 4 lay 2.4-fold (0.39 log units) below the measured number; measured number inside the range.
By their numbers in this assay, from the lowest: compound 1; then compounds 2, 3 and 4 (each within the scatter of the next).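

In this assay, going from 4-fluorophenyl to 4-(tert-butyl)phenyl on the carbonyl compounds gives a 1.1-fold higher number from compound 3 to compound 4 (0.03 log units; within the scatter), so the two compounds cannot be told apart. At this position, para to a large group, a group with more heavy atoms therefore leaves no readable mark, and the step between methyl and hydrogen on the sulfonyl compounds, a 5.1-fold higher number from compound 1 to compound 2 (0.70 log units; beyond the scatter), finds no echo in this change. Nothing available explains this result. As far as these compounds go, whether an amine or a carboxylic acid at this position would separate from fluoro on the carbonyl compounds stays open. So does how tert-butyl would read on a sulfonyl compound.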